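Hydrazide in place of ethyl amide on the shared core

A few compounds are considered here, and "the series" means these few. Any claim that something is new, unique, unknown or untested is made for them only; others in the source may bear on it.

Among the compounds with values here, compound 3 `CCNC(=O)c1oc2nc(-c3cccs3)cc(C(F)(F)F)c2c1N` gives the lowest of the three numbers so far, 62000 nM in an ADME assay on HEK293 cells (Homo sapiens) for antiproliferative activity, read by MTT assay (on this read-out higher numbers stand for weaker inhibition and lower numbers for stronger inhibition), but nothing separates it from its neighbours: compound 2 `CCCNC(=O)c1oc2nc(-c3cccs3)cc(C(F)(F)F)c2c1N` gives 64000 nM and the step of a 1.0-fold lower number from compound 2 to compound 3 (0.01 log units; within the scatter) is within the scatter, while compound 1 `Cc1ccc(/C=N/NC(=O)c2oc3nc(-c4cccs4)cc(C(F)(F)F)c3c2N)cc1` gives 78000 nM and the step of a 1.3-fold lower number from compound 1 to compound 3 (0.10 log units; within the scatter) is also within the scatter.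

Compound 4 `Nc1c(C(=O)N/N=C/c2ccc(Cl)cc2)oc2nc(-c3cccs3)cc(C(F)(F)F)c12` differs from compound 3 by a group of 9 heavy atoms (7 carbon, 1 nitrogen, 1 chlorine; one six-membered aromatic ring of carbon only) in place of a group of 2 heavy atoms (2 carbon; no ring), on an amide-type nitrogen. The entering group matches that of compound 1 except that it carries chlorine where compound 1 carries an additional carbon. The step of a 1.3-fold lower number from compound 1 to compound 3 (0.10 log units; within the scatter), read in reverse, is the one that bears on this change, and it was within the scatter, as was a 1.2-fold lower number from compound 1 to compound 2 (0.09 log units; within the scatter) for the related exchange on the same amide-type nitrogen. No step beyond the scatter is therefore expected, and the estimated step is a 1.2-fold higher number from compound 3 to compound 4 (0.08 log units; within the scatter). Compound 4 is expected to give about 75000 nM in this assay, within a range of 35000 nM to 160000 nM.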

Compound 4, half-maximal inhibitory concentration: 83000 nM
Compound 4: the middle estimate sits 1.1-fold (0.04 log units) below what was measured, and the stated range covers the measured number.
By their numbers in this assay, from the lowest: compounds 3, 2, 1 and 4 (each within the scatter of the next).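

Chloro in place of methyl on an aromatic carbon gives a 1.1-fold higher number from compound 1 to compound 4 (0.03 log units; within the scatter) in this assay, so this exchange on the aromatic ring of the entering group leaves the number within the scatter. The same holds for the whole group on the amide-type nitrogen, with a 1.3-fold higher number from compound 3 to compound 4 (0.13 log units; within the scatter) against ethyl and a 1.3-fold higher number from compound 2 to compound 4 (0.11 log units; within the scatter) against the smaller chain of compound 2, so among these four compounds neither the size of this group nor its ring substituent separates one from another. No measurement shown speaks to why the numbers stay so close.

On these data alone, whether a carboxylic acid in place of the amide, or an amine or a longer chain on the amide-type nitrogen, would give a step beyond the scatter remains open. Also open, as far as these compounds go, is whether the core itself sets this level, since every compound here shares the thiophene, trifluoromethyl and amine groups.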